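Bromo removed from compound 1: expected outcome for compound 3

The compounds below may be only part of what the source reports. "The series", "measured", "known", "first", "only" and "open" are said of these compounds alone.

Among the measured compounds shown here, compound 1 `O=[N+]([O-])C1=Cc2cc(Br)ccc2OC1C(F)(F)F` gives 3490 nM in a functional assay on 1321N1 cells for antagonist activity at P2Y purinoceptor 6 (Homo sapiens), read by fluorescence and calcium flux (a lower number here means a stronger inhibitor, a higher number a weaker inhibitor), the lowest of the two numbers so far; compound 2 `O=C1c2ccccc2C(=O)N1CC#Cc1ccc2c(c1)C=C([N+](=O)[O-])C(C(F)(F)F)O2` gives 4650 nM, which lies within the scatter of compound 1, so no order between them can be drawn. Compound 3 `O=[N+]([O-])C1=Cc2ccccc2OC1C(F)(F)F` differs from compound 1 by hydrogen in place of bromo on an aromatic carbon. For the measured compounds named here, no measured pair isolates this change. Since compound 2 gives 4650 nM, the series tolerates variation there, and the step of a 1.7-fold higher number from compound 1 to compound 3 (0.24 log units; within the scatter) is expected to be modest, toward weaker inhibition, near the edge of scatter. Compound 3 is estimated at 6000 nM, within 2500 nM to 15000 nM.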

Compound 3, half-maximal inhibitory concentration: 2910 nM
For compound 3 the middle estimate is 2.1-fold (0.31 log units) above the measured one; low and high end bracket the measured number.
By their numbers in this assay, from the lowest: compounds 3, 1 and 2 (each within the scatter of the next).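

In this assay, among the compounds shown here, hydrogen in place of bromo on an aromatic carbon gives a 1.2-fold lower number from compound 1 to compound 3 (0.08 log units; within the scatter) and supplies the first matched pair at this position. The bromine atom can be lost with no change beyond the scatter, so bromo is not required for inhibition at this level on the shared core. No measurement at hand bears on why the two compounds read alike.

On these data alone, whether an amine, a carboxylic acid or a longer chain on this carbon would shift the number beyond the scatter stays open. The contribution of the trifluoromethyl and nitro groups also stays open, as all compounds shown carry both.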